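The compounds below may be only part of what the source reports. "The series", "measured", "known", "first", "only" and "open" are said of these compounds alone.

Measured in a functional assay on HCT-116 cells (Homo sapiens) for cytotoxicity; on this read-out lower numbers stand for stronger inhibition and higher numbers for weaker inhibition:
- compound 1 `COc1cc(N2CCN(C(=O)C3CCC(O)CC3)CC2)ccc1Nc1nc(NC2CCCCC2)c2nc[nH]c2n1`: 15 nM
- compound 2 `COc1cc(N2CCN(C(=O)N3CCC(O)C3)CC2)ccc1Nc1nc(NC2CCCCC2)c2nc[nH]c2n1`: 27 nM
- compound 3 `COc1cc(N2CCC(C(=O)N3CCC(N(C)C)C3)CC2)ccc1Nc1nc(NC2CCCCC2)c2nc[nH]c2n1`: 58 nM

Compound 3 stands highest of the three in this assay, and its number lies beyond the usual scatter from both of the others, compound 2 at 27 nM and compound 1 at 15 nM. Compound 4 `COc1cc(N2CCC(CC(=O)N3CCCC3)CC2)ccc1Nc1nc(NC2CCCCC2)c2nc[nH]c2n1` has no number yet. Its difference from compound 3 counts as ((pyrrolidin-1-yl)carbonyl)methyl in place of (3-(dimethylamino)pyrrolidin-1-yl)carbonyl on a saturated ring carbon. In words, ((pyrrolidin-1-yl)carbonyl)methyl stands in place of (3-(dimethylamino)pyrrolidin-1-yl)carbonyl on a saturated ring carbon.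

Going by the values given here, no measured step covers this exchange directly. The closest is the change on a carbonyl carbon, 3-hydroxypyrrolidin-1-yl in place of 4-hydroxycyclohexyl, which gave a 1.8-fold higher number from compound 1 to compound 2 (0.26 log units; within the scatter). That single step is a thin guide, but it suggests a change of similar size in this assay, with no shift beyond the scatter expected. Any movement is expected to be towards a lower number, since compound 3 at 58 nM is the highest of the series so far. The estimate therefore means a 1.7-fold lower number from compound 3 to compound 4 (0.22 log units; within the scatter). Compound 4 is expected at 35 nM, with an estimated range from 14 nM to 90 nM.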

Compound 4, half-maximal inhibitory concentration: 15 nM
Estimate against measurement, compound 4: 2.3-fold (0.37 log units) above; the range from low to high includes it.
By their numbers in this assay, from the lowest: compounds 1, 4 and 2 (each within the scatter of the next); then compound 3.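

Going by these compounds alone, at the saturated ring carbon of the six-membered non-aromatic ring with 1 nitrogen, ((pyrrolidin-1-yl)carbonyl)methyl in place of (3-(dimethylamino)pyrrolidin-1-yl)carbonyl gives, in this assay, a 3.9-fold lower number from compound 3 to compound 4 (0.59 log units; beyond the scatter), a step beyond the scatter, whereas the one earlier step, on a carbonyl carbon, gave a 1.8-fold higher number from compound 1 to compound 2 (0.26 log units; within the scatter) and stayed within it. This position therefore shows a readable response to the group it carries, and the number falls even though the entering group has fewer heavy atoms and fewer hydrogen-bond acceptors than the group that leaves. No measurement at hand offers an explanation for this step.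

The exchange alters two things at once, adding a methyl link to the carbonyl and removing the dimethylamino group, and the compounds shown do not reveal how much of the step belongs to each. Going by these compounds, it also remains open how the number would respond to a longer chain carrying the carbonyl, or to a carboxylic acid or a primary amine at this ring carbon.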